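This account rests on a few compounds, and the source may have more. Where it says the series, first, only, none or still open, it means among the compounds named here.

The measured compounds:

Compound 1, `C[C@]1(c2ccc(O)cc2)CSc2cc(O)ccc2[C@H]1CCCCCCCCC(CCCC(F)(F)C(F)(F)F)C(=O)O`: 94%
Compound 2, `C[C@]1(c2ccc(O)cc2)CSc2cc(O)ccc2[C@H]1CCCCCCCCC(CCCCC(F)(F)C(F)(F)F)C(=O)O`: 97%

Both were tested in a functional assay on the whole organism for antagonist activity, with Mus musculus as the target, at a dose of 30 mg/kg by the oral route; a higher number here means a stronger effect of the compound at the dose given, a lower number a weaker effect. Compound 1 gives 94% in this assay, and compound 2 gives 97%. The only difference between them was a number 3 percentage points higher from compound 1 to compound 2 (within the scatter), so the two numbers lie within the scatter of each other and neither can be set apart from the other.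

Compound 3, `C[C@]1(c2ccc(O)cc2)CSc2cc(O)ccc2[C@H]1CCCCCCCCC(CCCCCC(F)(F)C(F)(F)F)C(=O)O`, has not been measured. It differs from compound 2 in one place: 2,2,3,3,3-pentafluoropropyl in place of 1,1,2,2,2-pentafluoroethyl on a saturated chain carbon, five bonds along the chain from a carbonyl carbon.

For the measured compounds named here, the one step that bears on this is the change from compound 1 to compound 2, which is the same kind of lengthening one bond nearer the carbonyl carbon, and its size was a number 3 percentage points higher from compound 1 to compound 2 (within the scatter). On that basis no step beyond the scatter is expected in this assay: the expected step is a number 2 percentage points lower from compound 2 to compound 3 (within the scatter). Compound 3 is therefore estimated at 95% in this assay, with a range from 85% to 100%.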

Compound 3, a percentage reported as inhibition, in the whole organism at one dose (the size of the read-out at that dose, not a potency): 94%
Estimate against measurement, compound 3: 1 percentage points above, within the range that was stated.
By their numbers in this assay, from the lowest: compounds 1, 3 and 2 (each within the scatter of the next).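

With one more chain length added, the step in this assay is a number 3 percentage points lower from compound 2 to compound 3 (within the scatter), and the larger change across the series gives no change at the digits printed from compound 1 to compound 3 (within the scatter). For the compounds shown here, the side chain at this position can therefore carry 1,1,2,2,2-pentafluoroethyl, 2,2,3,3,3-pentafluoropropyl or 3,3,4,4,4-pentafluorobutyl with no step that stands out from the scatter, so the three compounds show no trend with chain length, and because each was read at a single dose, this says nothing about their relative potency. Nothing in the data accounts for this flat result.

On these data alone, it remains open whether a much longer fluorinated chain, a plain hexyl chain without fluorine, or a chain ending in an amine would keep the effect at this position. It is also unknown whether the three compounds would separate at a lower dose.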